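A few compounds are considered here, and "the series" means these few. Any claim that something is new, unique, unknown or untested is made for them only; others in the source may bear on it.

Compound 1, `CCCCn1ccc2cc(/C(C)=C/C(=O)Nc3ccccc3OCCCC(=O)O)ccc21`, gives 43 nM in an assay on Prostate gland for inhibition of steroid 5-alpha-reductase (Rattus norvegicus); on this read-out higher numbers stand for weaker inhibition and lower numbers for stronger inhibition.
Compound 2, `C/C(=C\C(=O)Nc1ccccc1OCCCC(=O)O)c1ccc2c(ccn2Cc2ccc(C(F)(F)F)cc2)c1`, gives 300 nM.
Compound 3, `CCC(c1ccccc1)n1ccc2cc(/C(C)=C/C(=O)Nc3ccccc3OCCCC(=O)O)ccc21`, gives 19 nM.

Compound 3 stands lowest of the three numbers in this assay, with compound 1 nearest and compound 2 furthest, as the steps of a 2.3-fold lower number from compound 1 to compound 3 (0.35 log units; beyond the scatter) and a 16-fold lower number from compound 2 to compound 3 (1.20 log units; beyond the scatter) show. Compound 4, `C/C(=C\C(=O)Nc1ccccc1OCCCC(=O)O)c1ccc2c(ccn2C(c2ccccc2)C(C)C)c1`, differs from compound 3 by methyl in place of hydrogen on a saturated chain carbon bound to two saturated chain carbons. Going by the values given here, no measured step changes this chain in the same way: the steps of a 7.0-fold higher number from compound 1 to compound 2 (0.84 log units; beyond the scatter), a 2.3-fold lower number from compound 1 to compound 3 (0.35 log units; beyond the scatter) and a 16-fold lower number from compound 2 to compound 3 (1.20 log units; beyond the scatter) all swap whole groups on the aromatic nitrogen rather than adding one carbon to a chain already carrying a phenyl. A single added methyl is therefore expected to give no step beyond the scatter in this assay, which is a 1.1-fold higher number from compound 3 to compound 4 (0.02 log units; within the scatter). Compound 4 is estimated at 20 nM, within 8 nM to 50 nM.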

Compound 4, half-maximal inhibitory concentration: 25 nM
Compound 4: middle estimate off by 1.3-fold (0.10 log units), on the low side, and the stated range covers the measured number.
By their numbers in this assay, from the lowest: compounds 3, 4 and 1 (each within the scatter of the next, the first and the last beyond it); then compound 2.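

Adding the methyl that turns 1-phenylpropyl into 2-methyl-1-phenylpropyl gives no step beyond the scatter in this assay (a 1.3-fold higher number from compound 3 to compound 4 (0.12 log units; within the scatter)), so this chain carbon tolerates the extra methyl. The new group also stays within the scatter of butyl (a 1.7-fold lower number from compound 1 to compound 4 (0.24 log units; within the scatter)), yet it keeps a large distance from 4-(trifluoromethyl)benzyl (a 12-fold lower number from compound 2 to compound 4 (1.08 log units; beyond the scatter)). Nothing available explains these numbers.

From the compounds shown here alone, it remains open whether a larger group such as tert-butyl or cyclohexyl at this carbon would be tolerated as well. An amine or a hydroxyl on the same chain also remains untested in the compounds shown here.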